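Diisopropylamino in place of phenethyl on the carbonyl carbon

A few compounds are considered here, and "the series" means these few. Any claim that something is new, unique, unknown or untested is made for them only; others in the source may bear on it.

Compound 1 `O=C(O)c1nc(N2CCN(C(=O)COc3ccc(Cl)cc3)CC2)c2cc(F)sc2n1` gives in a functional assay on cells (Lymphocyte) (on this read-out higher numbers stand for weaker inhibition and lower numbers for stronger inhibition), only a limit, > 10000 nM, with no number reported for it. Compound 2 `Nc1nc(N2CCN(C(=O)CCc3ccccc3)CC2)c2cc(F)sc2n1` gives 6990 nM in this assay. Set against (the limit of > 10000 nM in this assay, at which 1 of the 2 values shown sits), compound 2 holds the only number in the set. Compound 3 `CC(C)N(C(=O)N1CCN(c2nc(N)nc3sc(F)cc23)CC1)C(C)C` is not yet measured; it differs from compound 2 in one place: diisopropylamino in place of phenethyl on a carbonyl carbon. Going by the values given here, no measured step matches this change. The step from compound 2 to compound 3 in this assay is expected to be a 1.1-fold higher number from compound 2 to compound 3 (0.06 log units; within the scatter), not beyond the usual scatter. Compound 3 is therefore expected at 8000 nM, in a range from 2500 nM to 25000 nM.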

Compound 3, half-maximal inhibitory concentration: 8200 nM
For compound 3 the middle estimate is 1.0-fold (0.01 log units) below the measured one, and the stated range covers the measured number.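

In this assay the change on the carbonyl carbon gives a 1.2-fold higher number from compound 2 to compound 3 (0.07 log units; within the scatter). Diisopropylamino, with no ring, thus reads the same as phenethyl, so the six-membered aromatic ring of phenethyl is not needed to hold this level of inhibition at this position. Compound 1 remains a limit, not a number: the limit of > 10000 nM in this assay, at which 1 of the 3 values shown sits.

Still open, from the compounds shown here alone, is whether a smaller group on this carbonyl carbon, such as dimethylamino or methyl, moves the number beyond the scatter. The same holds for a chain ending in a primary amine or a carboxylic acid.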